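Swapping an Amine Tail for a Carboxy Group

This account rests on a few compounds, and the source may have more. Where it says the series, first, only, none or still open, it means among the compounds named here.

Of the compounds shown here, three built on one shared core have been measured, and they differ only at a saturated chain carbon bound to a saturated ring carbon. Compound 1 `CC(C)C[C@@H]1NC(=O)[C@H](C)NC1=O` carries hydrogen there, compound 2 `CC(C)C[C@@H]1NC(=O)[C@H](Cc2cnc[nH]2)NC1=O` carries 1H-imidazol-5-yl, and compound 3 `CC(C)C[C@@H]1NC(=O)[C@H](CCCCN)NC1=O` carries 3-aminopropyl. In a functional assay, tested at 2.5 mM (on this read-out lower numbers stand for less inhibition and higher numbers for more inhibition at the one concentration tested (going by the name of the read-out)), compound 1 gives 0%, compound 2 gives 0% and compound 3 gives 0%. The steps among them, no change at the digits printed from compound 1 to compound 2 (within the scatter), no change at the digits printed from compound 1 to compound 3 (within the scatter) and no change at the digits printed from compound 2 to compound 3 (within the scatter), all stay within the scatter, so compound 3 stands level with compounds 1 and 2.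

Compound 4 `CC(C)C[C@@H]1NC(=O)[C@H](CC(=O)O)NC1=O` is the next step from compound 3: carboxy in place of 3-aminopropyl on a saturated chain carbon bound to a saturated ring carbon. For the measured compounds named here, the steps that bear on this change are those to compound 3 from compound 1 and from compound 2, each of which exchanged the group at the same carbon without any shift beyond the scatter. On that basis the step from compound 3 to compound 4 is expected to be no change at the digits printed from compound 3 to compound 4 (within the scatter), that is, none beyond the scatter. Compound 4 is therefore estimated at 0%, with a range from 0% to 10%.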

Compound 4, a percentage reported as inhibition, at one concentration (the size of the read-out at that concentration, not a potency): 0%
Beside the measured number, compound 4's estimate shows no gap at the digits printed; measured number inside the range.
By their numbers in this assay, from the lowest: compounds 1, 2, 3 and 4 (each within the scatter of the next).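

In this assay the carboxy group gives no change at the digits printed from compound 3 to compound 4 (within the scatter) and, set against the other two groups, no change at the digits printed from compound 2 to compound 4 (within the scatter) together with no change at the digits printed from compound 1 to compound 4 (within the scatter) at this saturated chain carbon bound to a saturated ring carbon. A carboxylic acid therefore joins 3-aminopropyl, 1H-imidazol-5-yl and hydrogen as a fourth group at this place, and the four compounds remain level, so this exchange adds no separation among them. Nothing at hand bears on why the read-out stays flat across these groups.

From the compounds shown here alone, whether a phenyl ring, an indole or a longer carboxylic acid chain at this carbon would shift the inhibition remains open. Going by these compounds, it is also open whether replacing the 2-methylpropyl group on the other side of the shared core would give any read-out at all.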